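The source may hold more compounds than are shown below. What is called first, only, known or untested is meant among the compounds shown, and "the series" means these compounds.

Measured compounds:
compound 1 `c1ccc(CNCC2CCN(CCCc3c[nH]c4ccc(-n5cnnc5)cc34)CC2)cc1` – 1.6 nM
compound 2 `C[C@@H](NC1CCN(CCCc2c[nH]c3ccc(-n4cnnc4)cc23)CC1)c1ccccc1` – 0.4 nM

In an assay on CHO cells for displacement of a labelled ligand from 5-hydroxytryptamine receptor 1D (Homo sapiens) (on this read-out lower numbers stand for stronger inhibition and higher numbers for weaker inhibition), compound 1 gives 1.6 nM, the highest of the two numbers; compound 2 gives 0.4 nM. Going by the values given here, the only measured step, a 4.0-fold lower number from compound 1 to compound 2 (0.60 log units; beyond the scatter), comes from swapping (1-phenylethyl)amino for (benzylamino)methyl on a saturated ring carbon.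

Compound 3 `CC(=O)Nc1ccc(CNCC2CCN(CCCc3c[nH]c4ccc(-n5cnnc5)cc34)CC2)cc1` differs from compound 1 in another way: acetamido in place of hydrogen on an aromatic carbon. The group enters on an aromatic carbon of a six-membered aromatic ring of carbon only, para to a large group. Among the compounds with values here, no measured step touches this ring, so the step from compound 1 to compound 2 bears on it only as a sign that the series tolerates change around the benzyl end without loss. Nothing in the data points in either direction for this change, so the expected step, a 1.3-fold higher number from compound 1 to compound 3 (0.10 log units; within the scatter), stays within the scatter. Compound 3 is therefore estimated at 2 nM, with a range of 0.6 nM to 7 nM.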

Compound 3, half-maximal inhibitory concentration: 4.2 nM
Compound 3: middle estimate off by 2.1-fold (0.32 log units), on the low side; low and high end bracket the measured number.
By their numbers in this assay, from the lowest: compound 2; then compound 1; then compound 3.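

Acetamido in place of hydrogen on an aromatic carbon, para to a large group, gives a 2.6-fold higher number from compound 1 to compound 3 (0.42 log units; beyond the scatter) in this assay, the first sign that the benzyl ring responds to substitution. The response is modest: the ring carries this group and compound 3 still reads 4.2 nM. Nothing at hand explains the size or direction of this step.

From the compounds shown here alone, it remains open whether the weaker number belongs to acetamido itself or would follow any group at this place; fluorine, methoxy or a free amine on the same carbon would help separate the two. Also open, going by these compounds, is whether the same change would give a similar step on the phenyl ring of compound 2, which carries (1-phenylethyl)amino on the saturated ring carbon.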